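The compounds below may be only part of what the source reports. "The series", "measured", "known", "first", "only" and "open" are said of these compounds alone.

Of the compounds shown here, three sharing one core have been measured in an in vitro assay on HEK385-7 cells for displacement of a labelled ligand from prostaglandin D2 receptor 2 (Homo sapiens); a lower number here means a stronger inhibitor, a higher number a weaker inhibitor. Compound 1 `O=C(O)Cc1sc(C(c2ccccc2)c2ccccc2)nc1-c1ccccc1` gives 570 nM. Compound 3 `O=C(O)Cc1sc(C(c2ccccc2)c2ccccc2)nc1-c1ccc(C(F)(F)F)cc1`, which carries a trifluoromethyl in place of hydrogen on an aromatic carbon, gives 1100 nM; the step of a 1.9-fold higher number from compound 1 to compound 3 (0.29 log units; within the scatter) lies within the scatter. Compound 2 `O=C(O)Cc1sc(C(c2ccc(F)cc2)c2ccc(F)cc2)nc1-c1ccnc(F)c1` gives 0.48 nM, the lowest number of the three: both compound 1 and compound 3 lie far higher, and both gaps are beyond the scatter. Among the measured compounds shown here, compound 2 differs from compound 1 in more than one place, so the two values show only that the combination of changes goes together with a much stronger binder; no single step can be read off.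

Compound 4 `NS(=O)(=O)c1cccc(-c2nc(C(c3ccc(F)cc3)c3ccc(F)cc3)sc2CC(=O)O)c1` has not yet been measured. It differs from compound 2 in one place: 3-sulfamoylphenyl in place of 2-fluoropyridin-4-yl on an aromatic carbon. For the measured compounds named here, the only measured step at this place, a 1.9-fold higher number from compound 1 to compound 3 (0.29 log units; within the scatter), was small, but it exchanged a hydrogen for trifluoromethyl on a phenyl, not one whole aromatic ring for another, so it is a weak guide. A larger step than the scatter is expected, toward a higher number, since nothing measured supports keeping the exceptionally low number of compound 2 after so broad an exchange. Compound 4 is therefore estimated at 3 nM, between 0.5 nM and 20 nM, a step of a 6.3-fold higher number from compound 2 to compound 4 (0.80 log units; beyond the scatter).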

Compound 4, half-maximal inhibitory concentration: 140 nM
Beside the measured number, compound 4's estimate is 47-fold (1.67 log units) below it; measured number outside the range, above it.
By their numbers in this assay, from the lowest: compound 2; then compound 4; then compounds 1 and 3 (each within the scatter of the next).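

In this assay, putting 3-sulfamoylphenyl in place of 2-fluoropyridin-4-yl gives a 290-fold higher number from compound 2 to compound 4 (2.46 log units; beyond the scatter), so this position, next to the ring nitrogen, can respond strongly to which aromatic group it carries. The earlier step here, a 1.9-fold higher number from compound 1 to compound 3 (0.29 log units; within the scatter), stayed within the scatter, but it only added trifluoromethyl to a phenyl ring on a different background, whereas this exchange replaces the whole ring and shows that a six-membered aromatic ring at this place does not by itself keep the number low. The exchange changes several things at once, including the ring nitrogen, the fluorine and the new sulfamoyl group with its hydrogen-bond donor, and nothing available here says which of these accounts for the step.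

The compounds shown leave open whether the large step comes from losing the fluoropyridine or from adding the sulfamoyl group, a question that an unsubstituted phenyl or pyridin-4-yl on the core of compound 2 would help to separate. They also leave open how this position would respond to a phenyl ring carrying an amine or a carboxylic acid in place of the sulfamoyl group.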